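Working notes: amine variants on the fused core

This account rests on a few compounds, and the source may have more. Where it says the series, first, only, none or still open, it means among the compounds named here.

Among the compounds with values here, compound 3 `Cc1nc2c(OCc3ccccc3)cccn2c1CN` gives 9% in a functional assay on the whole organism with Canis familiaris (Canis lupus familiaris) as the target, at a dose of 8 mg/kg by the oral route (a lower number here means a weaker effect, a higher number a stronger effect of the compound at the dose given), the lowest of the three numbers so far. Compound 2 `Cc1ccn2c(N)c(C)nc2c1OCc1ccccc1` gives 64%, beyond the scatter above compound 3, and compound 1 `Cc1nc2c(OCc3ccsc3)cccn2c1N` gives 88%, the furthest from compound 3 and also beyond the scatter. Compound 4 `Cc1nc2c(OCc3ccccc3)cccn2c1N(C)C` is not yet measured and differs from compound 3 in one place: dimethylamino in place of aminomethyl on an aromatic carbon. Within the data shown here, no step between two measured compounds that differ in one place is available, so the size of this change is unknown. Because compound 1 with an amino group gives 88% and compound 2 gives 64% while compound 3 with aminomethyl gives 9%, a rise beyond the scatter is expected, a number 26 percentage points higher from compound 3 to compound 4 (beyond the scatter), with wide uncertainty. Compound 4 is estimated at 35%, between 5% and 70%.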

Compound 4, a percentage reported as inhibition, in the whole organism at one dose (the size of the read-out at that dose, not a potency): 72%
For compound 4 the middle estimate is 37 percentage points below the measured one, outside the stated range (above it).
By their numbers in this assay, from the lowest: compound 3; then compounds 2 and 4 (each within the scatter of the next); then compound 1.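

Within the data shown here, this is the first step on the shared core that changes only one place: on an aromatic carbon of the five-membered ring, dimethylamino in place of aminomethyl gives in this assay a number 63 percentage points higher from compound 3 to compound 4 (beyond the scatter) on a large scale. The read-out at this dose therefore depends strongly on the group at this position. Nothing measured here gives a reason for the step.

On these data alone, it remains open whether methylamino or a pyrrolidine ring at this place would hold the number of compound 4. The compounds shown also cannot separate the effect of the carbon link in aminomethyl from that of the two methyl groups on nitrogen.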